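This account rests on a few compounds, and the source may have more. Where it says the series, first, only, none or still open, it means among the compounds named here.

Compound 1 `Cc1ccc(C(=O)N(C(=S)OCCN2C(=O)c3ccccc3C2=O)c2ccc(Cl)cc2)cc1` carries a carbonyl group with a 4-methylphenyl on it, set on an amide-type nitrogen within the shared core. In an ADME assay on MT4 cells (Homo sapiens) for cytotoxicity, read by MTT assay (a higher number here means that more compound is tolerated, a lower number that less compound is tolerated), compound 1 gives > 100000 nM, and this is a limit of the assay rather than a measured number. Compound 2 `O=C1c2ccccc2C(=O)N1CCOC(=S)N(C(=O)c1cccnc1Cl)c1ccc(Br)cc1` is built on the same core. In this assay compound 2 gives > 100000 nM, which is again a limit and not a number. All that the measurements offer so far is the limit of > 100000 nM in this assay, at which 2 of the 2 values shown sit. Among the measured compounds shown here, compound 1 therefore stands where every value seen so far stands, at the edge of what this assay can report, and no step between two measured compounds is available to show how far a change in structure moves the read-out.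

Compound 3 `O=C1c2ccccc2C(=O)N1CCOC(=S)N(C(=O)c1cccc(Cl)c1Cl)c1ccc(Cl)cc1` differs from compound 1 in a single place: 2,3-dichlorophenyl in place of 4-methylphenyl on a carbonyl carbon. For the measured compounds named here, with no measured step to lean on, the expected step in this assay is a number no higher from compound 1 to compound 3 (the limit leaves the size open), that is, none beyond the scatter. For compound 3 the estimate in this assay is 100000 nM, with a range from 40000 nM to 200000 nM.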

Compound 3, half-maximal cytotoxic concentration: 54000 nM
For compound 3 the middle estimate is 1.9-fold (0.27 log units) above the measured one, and the stated range covers the measured number.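

Among the compounds shown here, compound 3 is the first compound here to give a real number rather than a limit in this assay, where compound 3 gives 54000 nM, so a change on this carbonyl carbon can bring the read-out within what the assay reports. On these data alone, putting 2,3-dichlorophenyl in place of 4-methylphenyl gives an at least 1.8-fold lower number from compound 1 to compound 3 (0.26 log units; that floor lies within the scatter); that figure is only a floor set by a limit, and the true size of the step stays open. The other values still sit at the edge of what can be reported: the limit of > 100000 nM in this assay, at which 2 of the 3 values shown sit.

As far as these compounds go, whether the number for compound 3 goes with the two chlorines or with the loss of the methyl stays open. So does what a plain phenyl, or a phenyl carrying an amine or a carboxylic acid, would give on this same carbonyl carbon in this assay.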